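The compounds below may be only part of what the source reports. "The series", "measured", "known", "first", "only" and "open" are said of these compounds alone.

Series notes, whole-animal agonist readout.

Compound 1, `CC(=O)N(C)C(C)C#CCn1cncc1C`, gives in a functional assay on the whole organism for agonist activity, with Mus musculus as the target (a lower number here means that less compound is needed, a higher number that more compound is needed for the effect), only a limit, > 100 mg/kg; the value sits at the limit of > 100 mg/kg in this assay, at which 1 of the 2 values shown sits, and is not a number. Within the data shown here, compound 2, `CC(=O)N(C)CC#CCn1cncc1C`, gives in this assay a value of 45 mg/kg, the only number in the set so far. Among the measured compounds shown here, the one measured step is an at least 2.2-fold lower number from compound 1 to compound 2 (0.34 log units; beyond the scatter), which removes a methyl from the chain carbon bound to the amide-type nitrogen and the triple-bonded carbon; since it starts from a limit, its true size is open beyond the bound given.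

Compound 3 is `COC(=O)N(C)CC#CCn1cncc1C`. It differs from compound 2 at the carbonyl: methoxy in place of methyl on a carbonyl carbon, that is, acetyl to methoxycarbonyl. For the measured compounds named here, no measured step touches the carbonyl substituent; the chain change from compound 1 to compound 2 lies elsewhere and gives no lead on this position. With nothing to anchor a direction, the expectation for compound 3 is a step of about no change at the digits printed from compound 2 to compound 3 (within the scatter), within the scatter. Compound 3 is therefore estimated at 45 mg/kg in this assay, expected between 18 mg/kg and 110 mg/kg.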

Compound 3, dose for half-maximal effect: > 100 mg/kg
Compound 3: no number, only a limit; the forecaster's own chance of this, stated with the estimate: 25%; middle value at least 2.2-fold (0.34 log units) away from the limit.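

The carbonyl substituent is not a neutral position in this assay: methoxy in place of methyl on a carbonyl carbon, acetyl to methoxycarbonyl, gives an at least 2.2-fold higher number from compound 2 to compound 3 (0.34 log units; beyond the scatter). The reading for compound 3 is a limit and not a number, so the size of this step is open beyond the bound, and compound 3 now shares its limit with compound 1: the limit of > 100 mg/kg in this assay, at which 2 of the 3 values shown sit. Among these compounds, the earlier step showed sensitivity only at the chain carbon; the series now shows it at the carbonyl as well, and compound 2 is the only compound with a number, while each of its two single-place neighbours sits at the limit.

With compound 1 and compound 3 both at a limit and differing in more than one place, nothing here orders them against each other, and no comparison between them can be read. From the compounds shown here alone, it remains open whether ethyl, which carries no oxygen, or an amine such as dimethylamino on the carbonyl carbon would read like acetyl or like methoxycarbonyl, and so whether the step follows the oxygen of the methoxy or simply any change from methyl.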